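Phenol replacing chloromethylphenyl at the quaternary carbon

This account rests on a few compounds, and the source may have more. Where it says the series, first, only, none or still open, it means among the compounds named here.

Compound 1 `COc1ccc(C2(c3cc(C(C)(C)C)ccc3O)C(=O)Nc3ccccc32)cc1` gives 15700 nM in a functional assay on cells (Mus musculus) for antiproliferative activity, read by sulforhodamine B assay, with a stated time of 5 days; on this read-out higher numbers stand for weaker inhibition and lower numbers for stronger inhibition.
Compound 2 `Cc1cc(C2(c3cc(C(C)(C)C)ccc3O)C(=O)Nc3ccccc32)ccc1Cl` gives 4300 nM in this assay.
Compound 3 `CC(C)(C)c1ccc(O)c(C2(c3ccccc3)C(=O)Nc3ccc(OC(F)(F)F)cc32)c1` gives 8000 nM in this assay.

Compound 2 stands lowest of the three numbers; compound 3 sits nearby, the gap within the scatter, while compound 1 lies clearly higher. Compound 4 `CC(C)(C)c1ccc(O)c(C2(c3ccc(O)cc3)C(=O)Nc3ccccc32)c1` has not yet been measured in this assay. It differs from compound 2 in one place: 4-hydroxyphenyl in place of 4-chloro-3-methylphenyl on a saturated ring carbon. Among the compounds with values here, only one measured step bears on this position, a 3.7-fold lower number from compound 1 to compound 2 (0.56 log units; beyond the scatter), which ran from 4-methoxyphenyl to the group now leaving. Going the other way, towards an oxygen-bearing aryl again, is expected to move the number back up, though no measured compound carries 4-hydroxyphenyl at this carbon, so the size is uncertain. The expected step is a 2.3-fold higher number from compound 2 to compound 4 (0.37 log units; beyond the scatter), upward and modest. Compound 4 is estimated at 10000 nM, with a range between 3500 nM and 30000 nM.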

Compound 4, half-maximal inhibitory concentration: 17300 nM
Compound 4: middle estimate off by 1.7-fold (0.24 log units), on the low side; low and high end bracket the measured number.
By their numbers in this assay, from the lowest: compounds 2, 3, 1 and 4 (each within the scatter of the next, the first and the last beyond it).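

In this assay, 4-hydroxyphenyl in place of 4-chloro-3-methylphenyl on the saturated ring carbon costs about as much as the earlier step from 4-methoxyphenyl gained (a 4.0-fold higher number from compound 2 to compound 4 (0.60 log units; beyond the scatter)). Hydrogen in place of methyl on the aryl oxygen gives no readable separation (a 1.1-fold higher number from compound 1 to compound 4 (0.04 log units; within the scatter)), so the free hydroxyl and its methyl ether do not differ in this read-out, and in these three compounds the lower number goes with 4-chloro-3-methylphenyl. No measurement here accounts for the gap between these aryl groups.

Chlorine and methyl enter together in compound 2, so their separate shares remain open. Also open, on these data alone, is how an aminophenyl group or a benzoic acid group at this carbon would compare with the oxygen-bearing aryl groups and with compound 2.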